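The source may hold more compounds than are shown below. What is called first, only, known or untested is meant among the compounds shown, and "the series" means these compounds.

Measured so far:
compound 1, `CC#C[C@@H](CC(=O)O)c1ccc(OC[C@H]2COc3ccc(Cl)cc3O2)cc1`: 50 nM
compound 2, `CC#C[C@@H](CC(=O)O)c1ccc(OC[C@@H]2COc3ccc(Cl)cc3O2)cc1`: 260 nM

In a functional assay on HEK293 cells for agonist activity at Free fatty acid receptor 1 (Homo sapiens), read by fluorescence and calcium flux, with a stated time of 10 min (a higher number here means that more compound is needed for the effect, a lower number that less compound is needed), compound 1 gives 50 nM and stands lowest of the two numbers; the nearer and only neighbour is compound 2, which gives 260 nM, a step of a 5.2-fold higher number from compound 1 to compound 2 (0.72 log units; beyond the scatter). That step rests on the fact that compounds 1 and 2 differ only in the configuration as drawn alone and leaves the substituted aromatic ring of the shared core untouched.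

Compound 3, `CC#C[C@@H](CC(=O)O)c1ccc(OC[C@H]2COc3ccc(C)cc3O2)cc1`, is not yet measured. Its change from compound 1 is methyl in place of chloro on an aromatic carbon: the methyl takes the place of the chloro on the aromatic carbon of the fused system, meta to a fused ring and para to a fused ring. Among the measured compounds shown here, no measured step alters a group at this carbon, so none bears on it directly; the stereochemical step is the only reference and is of a different kind. The expectation is therefore a step of a 1.5-fold higher number from compound 1 to compound 3 (0.18 log units; within the scatter), not clearly beyond the scatter in either direction. Compound 3 is estimated at 75 nM, expected between 25 nM and 250 nM.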

Compound 3, half-maximal effective concentration: 120 nM
Estimate against measurement, compound 3: 1.6-fold (0.20 log units) below; the range from low to high includes it.
By their numbers in this assay, from the lowest: compound 1; then compound 3; then compound 2.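

In this assay, among the compounds shown here, methyl in place of chloro on the aromatic carbon gives a 2.4-fold higher number from compound 1 to compound 3 (0.38 log units; beyond the scatter) and is the only measured change at this carbon. The position therefore registers an exchange of one heavy atom for another, even with no change in the counted hydrogen-bond donors, hydrogen-bond acceptors or net charge, and chloro gives the lower number of this pair. Nothing available gives a reason for this step.

The compounds shown leave open how a fluoro, methoxy or nitrile group at this carbon would read against chloro and methyl. They also leave open whether the same exchange would give a similar step in the configuration of compound 2, where the saturated ring carbon is drawn R.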